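This account rests on a few compounds, and the source may have more. Where it says the series, first, only, none or still open, it means among the compounds named here.

Working notes on the series. In a functional assay on SH-SY5Y cells (Homo sapiens) for antiproliferative activity, read by MTT assay, with a stated time of 72 h (a lower number here means a stronger inhibitor, a higher number a weaker inhibitor), compound 1 (`COc1cc2c(Nc3ccc(C#N)cc3)ncnc2cc1OCCCN1CCCC1`) gives 8080 nM and compound 2 (`COc1cc2c(Nc3ccc(C#N)cc3)ncnc2cc1OCCCN1CCC(c2ccccc2)CC1`) gives 7770 nM as its value. The two stand level within the scatter, so compound 2 holds no rank of its own against compound 1.

Compound 3 (`CCN1CCN(CCCOc2cc3ncnc(Nc4ccc(C#N)cc4)c3cc2OC)CC1`) keeps the shared core and the chain of compound 2 and changes only the chain end. It carries 4-ethylpiperazin-1-yl in place of 4-phenylpiperidin-1-yl on a saturated chain carbon, three bonds along the chain from an oxygen on an aromatic ring.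

Going by the values given here, one measured step bears on this place. That step (a 1.0-fold lower number from compound 1 to compound 2 (0.02 log units; within the scatter)) put 4-phenylpiperidin-1-yl in place of pyrrolidin-1-yl and lies within the scatter. Among the compounds with values here, it is thin evidence, since no compound with 4-ethylpiperazin-1-yl has a number yet, and it gives no direction.

The expected step (a 1.0-fold higher number from compound 2 to compound 3 (0.01 log units; within the scatter)) in this assay is therefore none beyond the scatter. The estimate for compound 3 is 8000 nM (expected range 3500 nM to 18000 nM).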

Compound 3, half-maximal inhibitory concentration: 5440 nM
Compound 3: the middle estimate sits 1.5-fold (0.17 log units) above what was measured, and the stated range covers the measured number.
By their numbers in this assay, from the lowest: compounds 3, 2 and 1 (each within the scatter of the next).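

In this assay, the chain end on a saturated chain carbon, three bonds along the chain from an oxygen on an aromatic ring, now spans three groups, and 4-ethylpiperazin-1-yl stays within the scatter of both others: a 1.4-fold lower number from compound 2 to compound 3 (0.15 log units; within the scatter) against 4-phenylpiperidin-1-yl and a 1.5-fold lower number from compound 1 to compound 3 (0.17 log units; within the scatter) against pyrrolidin-1-yl. The earlier pair left the second ring hetero atom untested, and this result adds it: 4-ethylpiperazin-1-yl, with 8 heavy atoms and 2 hetero atoms in its ring, reads level with 4-phenylpiperidin-1-yl, with 12 heavy atoms and an aromatic ring, so neither difference separates the numbers at this place. Nothing at hand bears on why the three compounds read level.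

Going by these compounds, whether any chain end gives a number beyond the scatter of these three stays open, for example morpholin-4-yl, a primary amine or a carboxylic acid in its place, or the same groups on a longer chain. On these data alone, all three compounds also keep the nitrile and the shared core, so the effect of a change there, such as a chlorine in place of the nitrile, stays open as well.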